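Fluorine added to the nitrophenyl ether of compound 1

This account rests on a few compounds, and the source may have more. Where it says the series, first, only, none or still open, it means among the compounds named here.

Compound 1 `CC(C)[C@H](NC(=O)COc1cccc2ccccc12)C(=O)N[C@@H](CC(=O)O)C(=O)COc1ccc([N+](=O)[O-])cc1` gives 22800 nM in a functional assay with Homo sapiens as the target (on this read-out lower numbers stand for stronger inhibition and higher numbers for weaker inhibition), the highest number among the three measured: compound 2 `CC(C)[C@H](NC(=O)COc1cccc2ccccc12)C(=O)N[C@@H](CC(=O)O)C(=O)COc1ccccc1F` gives 15700 nM and compound 3 `CC(C)[C@H](NC(=O)COc1cccc2ccccc12)C(=O)N[C@@H](CC(=O)O)C(=O)COc1c(F)c(F)cc(F)c1F` gives 6250 nM. Compound 4 `CC(C)[C@H](NC(=O)COc1cccc2ccccc12)C(=O)N[C@@H](CC(=O)O)C(=O)COc1ccc([N+](=O)[O-])cc1F` differs from compound 1 by fluoro in place of hydrogen on an aromatic carbon, so that 4-nitrophenyl becomes 2-fluoro-4-nitrophenyl. For the measured compounds named here, the steps that bear on this all change the aryl ether: a 1.5-fold lower number from compound 1 to compound 2 (0.16 log units; within the scatter); a 3.6-fold lower number from compound 1 to compound 3 (0.56 log units; beyond the scatter); a 2.5-fold lower number from compound 2 to compound 3 (0.40 log units; beyond the scatter). A single fluorine on the ring gave nothing beyond the scatter, and only the tetrafluorophenyl produced a modest lowering. One added fluoro with the nitro group retained is therefore expected to give a small step, a 1.5-fold lower number from compound 1 to compound 4 (0.18 log units; within the scatter), likely within the scatter. For compound 4 the estimate in this assay is 15000 nM, with a range from 7000 nM to 35000 nM.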

Compound 4, half-maximal inhibitory concentration: 15800 nM
Beside the measured number, compound 4's estimate is 1.1-fold (0.02 log units) below it; the measured number falls inside the stated range.
By their numbers in this assay, from the lowest: compound 3; then compounds 2, 4 and 1 (each within the scatter of the next).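

Fluoro on this aromatic carbon, ortho to a large group and meta to a nitro group, gives a 1.4-fold lower number from compound 1 to compound 4 (0.16 log units; within the scatter) in this assay, so this single atom makes no readable difference here. Nitro added to the 2-fluorophenyl ring gives a 1.0-fold higher number from compound 2 to compound 4 (0.00 log units; within the scatter) and is equally unreadable, whereas replacing the 2,3,5,6-tetrafluorophenyl ring with 2-fluoro-4-nitrophenyl gives a 2.5-fold higher number from compound 3 to compound 4 (0.40 log units; beyond the scatter) and keeps compound 3 apart. No supporting data explain these steps.

From the compounds shown here alone, whether an amine or a methoxy group on this same carbon would give a step beyond the scatter remains open. Also open, going by these compounds, is how further fluoro groups on the 2-fluoro-4-nitrophenyl ring would read.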